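Methyl for Fluoro: Expected Permeability of Compound 3

The compounds below may be only part of what the source reports. "The series", "measured", "known", "first", "only" and "open" are said of these compounds alone.

Measured compounds:
- compound 1, `Cc1oc(-c2ccc(F)cc2)nc1CN1CCC(C(=O)NCCCN2C[C@H](C)C[C@H](C)C2)CC1`: "not determined" (no result reported)
- compound 2, `CCCN(CCC)CCNC(=O)C1CCN(Cc2nc(-c3ccccc3C)oc2C)CC1`: 913 10^-6 cm/s

In a physicochemical assay for permeability, using PAMPA (a lower number here means that the compound crosses the layer more slowly, a higher number that the compound crosses the layer faster), compound 1 stands at "not determined" (no result reported); its position in this assay is therefore unknown. Going by the values given here, compound 2 is the only compound with a result, and in this assay compound 2 gives 913 10^-6 cm/s, a fast crossing of the layer. Among the compounds with values here, no step between measured compounds is available, so compound 2 serves only as a reference point for the class.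

Compound 3, `Cc1ccc(-c2nc(CN3CCC(C(=O)NCCCN4C[C@H](C)C[C@H](C)C4)CC3)c(C)o2)cc1`, differs from compound 1 in one place: methyl in place of fluoro on an aromatic carbon. The change is one heavy atom for one heavy atom, with no ring, no hydrogen-bond donor or acceptor and no charge gained or lost. For a change of this kind no step beyond the usual scatter of this assay is expected, in either direction; with nothing measured for compound 1, the expectation rests on compound 2 alone.

Compound 3 is therefore expected to cross the layer quickly, estimated at 800 10^-6 cm/s, with a likely range from 350 10^-6 cm/s to 1600 10^-6 cm/s.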

Compound 3, apparent permeability: 274 10^-6 cm/s
For compound 3 the middle estimate is 2.9-fold (0.47 log units) above the measured one, and the stated range ends above it.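

In this assay, going by these compounds alone, compound 1 stands at "not determined" (no result reported) and compound 3 gives 274 10^-6 cm/s and so no step between compound 1 and compound 3 can be read. Going by these compounds, what the change from 4-fluorophenyl to 4-methylphenyl does to this read-out stays open. Nothing shown bears on the value of compound 3.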